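The source may report more compounds than this note shows. Statements on the series, on what has been measured and on what is new or still open speak of the compounds shown alone.

Compound 1 (`COc1ccc(/C=C2\CCC=CC2=O)cc1`) stands at 2570 nM in a functional assay on MCF7 cells (Homo sapiens) for antiproliferative activity, read by sulforhodamine B assay, with a stated time of 72 h (a lower number here means a stronger inhibitor, a higher number a weaker inhibitor), while compound 2 (`COc1ccc(/C=C2\CCC=CC2=O)cc1OC`) stands at 5230 nM and compound 3 (`COc1cc(/C=C2\CCC=CC2=O)cc(OC)c1OC`) at 5260 nM on the same scale. Compound 2 therefore sits level with compound 3 and apart from compound 1. The unmeasured compound 4 (`COc1ccc(/C=C2\CCC=CC2=O)cc1[N+](=O)[O-]`) keeps the core of compound 2 but carries nitro in place of methoxy on an aromatic carbon. Two measured steps offer a guide, though both concern methoxy in place of hydrogen rather than nitro. The modest step of a 2.0-fold higher number from compound 1 to compound 2 (0.31 log units; beyond the scatter) places methoxy on the very carbon that changes here, whereas the step of a 1.0-fold higher number from compound 2 to compound 3 (0.00 log units; within the scatter) adds methoxy elsewhere and stays within the scatter. Losing that methoxy might therefore shift the number back towards compound 1, although no nitro compound has been measured to confirm this. The expected result in this assay is a small move towards a lower number, estimated as a 1.6-fold lower number from compound 2 to compound 4 (0.21 log units; within the scatter) overall. For compound 4 the estimated value is 3200 nM (expected range 1100 nM to 9000 nM).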

Compound 4, half-maximal inhibitory concentration: 1680 nM
Compound 4: middle estimate off by 1.9-fold (0.28 log units), on the high side; the range from low to high includes it.
By their numbers in this assay, from the lowest: compounds 4 and 1 (each within the scatter of the next); then compounds 2 and 3 (each within the scatter of the next).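

In this assay the carbon ortho to a methoxy group turns out to respond to which group it carries, not only to whether methoxy is present: nitro in place of methoxy gives a 3.1-fold lower number from compound 2 to compound 4 (0.49 log units; beyond the scatter), a move opposite in direction to the earlier gain of methoxy on that same carbon. Nitro and hydrogen on this carbon cannot be told apart, as the step of a 1.5-fold lower number from compound 1 to compound 4 (0.18 log units; within the scatter) shows, so among these three groups methoxy alone stands apart here. No measurement is available that explains this difference between methoxy and nitro.

The compounds shown leave open how an amine, a carboxylic acid or a longer chain such as ethoxy would fare on this carbon. They also leave open whether nitro would give the same result on another carbon of the aromatic ring.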